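The compounds below may be only part of what the source reports. "The series", "measured", "known", "first", "only" and "open" are said of these compounds alone.

Working notes on the series, all read in a functional assay on SH-SY5Y cells (Homo sapiens) for cytotoxicity, read by MTT assay, with a stated time of 72 h; a lower number here means a stronger inhibitor, a higher number a weaker inhibitor. Compound 1 `O=C1c2c[n+]([O-])c3ccccc3c2C(=O)c2c1c1ccccc1n2Cc1cn(C[C@H](O)CO)nn1` gives > 1000 nM, which is a limit of the assay and not a number. Compound 2 `O=C1c2c[n+]([O-])c3ccccc3c2C(=O)c2c1c1ccccc1n2CCCCN1CCNCC1` gives 1240 nM, and compound 3 `CCCN1CCN(CCCCn2c3c(c4ccccc42)C(=O)c2c[n+]([O-])c4ccccc4c2C3=O)CC1` gives 3970 nM. Compound 3 therefore holds the higher of the two actual numbers, with a 3.2-fold higher number from compound 2 to compound 3 (0.51 log units; beyond the scatter) for propyl in place of hydrogen on an amine nitrogen in a ring.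

Compound 4 `O=C1c2c[n+]([O-])c3ccccc3c2C(=O)c2c1c1ccccc1n2Cc1cn(C[C@@H](O)CO)nn1` is still unmeasured. The structural change on going to it from compound 3 is: 1-(2,3-dihydroxypropyl)-1H-1,2,3-triazol-4-yl in place of 3-(4-propylpiperazin-1-yl)propyl on a saturated chain carbon bound to an aromatic nitrogen. Thus 1-(2,3-dihydroxypropyl)-1H-1,2,3-triazol-4-yl replaces 3-(4-propylpiperazin-1-yl)propyl on a saturated chain carbon bound to an aromatic nitrogen. Compound 1 carries the same entering group and differs from compound 4 at the defined stereocentre.

The nearest measured exchange is the reverse one: a step that the limit leaves unreadable from compound 1 to compound 3. On these data alone, the related step that the limit leaves unreadable from compound 1 to compound 2 is equally open. Going by the values given here, the one readable step, a 3.2-fold higher number from compound 2 to compound 3 (0.51 log units; beyond the scatter), concerns a different change and sets no size here. As far as these compounds go, no step beyond the scatter is therefore expected, though either direction remains open. The expected step is a 1.0-fold higher number from compound 3 to compound 4 (0.00 log units; within the scatter). The estimated value for compound 4 is 4000 nM, with an expected range of 1200 nM to 15000 nM.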

Compound 4, half-maximal inhibitory concentration: > 500 nM
Compound 4: only a limit was reported; the forecaster's own chance of this, stated with the estimate: 65%; the middle value does not contradict the limit.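

Compound 4 gives > 500 nM in this assay, which is a limit of the assay and not a number. Going by these compounds alone, no new step can therefore be read from compound 1, compound 2 or compound 3 to compound 4. The compounds shown leave open whether the configuration at the stereocentre changes the result, and how far compound 1 and compound 4 lie from compound 2 and compound 3.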